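The source may report more compounds than this note shows. Statements on the series, on what has been measured and on what is new or still open speak of the compounds shown alone.

Compound 2 `CCCCCCCCN(C)S(=O)(=O)NC(=O)Oc1c(C(C)(C)C)cc(C)cc1C(C)(C)C` gives 18000 nM in an assay on liver for inhibition of sterol O-acyltransferase 1 (Rattus norvegicus), using microsomes (on this read-out higher numbers stand for weaker inhibition and lower numbers for stronger inhibition), the higher of the two numbers recorded so far, and compound 1 `CCCCN(CCCC)S(=O)(=O)NC(=O)Oc1c(C(C)(C)C)cc(C)cc1C(C)(C)C` gives 3200 nM in this assay. Among the compounds with values here, the single step between them, a 5.6-fold higher number from compound 1 to compound 2 (0.75 log units; beyond the scatter), replaces dibutylamino with methyl(octyl)amino on the sulfonyl sulfur and weakens the inhibition.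

Compound 3 `CCCCCCCCN(CCCCCCCC)S(=O)(=O)NC(=O)Oc1c(C(C)(C)C)cc(C)cc1C(C)(C)C` carries the change (heptyl in place of hydrogen on a saturated chain carbon bound to a sulfonamide nitrogen), so that the amino group on the sulfonyl sulfur now bears two octyl chains. Within the data shown here, no measured step follows the same direction of change: the only step in hand exchanges two butyl chains for a methyl and an octyl chain while compound 3 lengthens the methyl chain itself. That step, a 5.6-fold higher number from compound 1 to compound 2 (0.75 log units; beyond the scatter), shows that rearranging the chains on the sulfonamide nitrogen moves this assay by a modest amount beyond the scatter, but it does not say in which direction a second octyl chain will push. The expectation for compound 3 is therefore a step of a 1.5-fold lower number from compound 2 to compound 3 (0.18 log units; within the scatter), not clearly beyond the scatter, with the estimate for compound 3 at 12000 nM and a range from 3000 nM to 50000 nM.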

Compound 3, half-maximal inhibitory concentration: 2700 nM
Compound 3: the middle estimate sits 4.4-fold (0.65 log units) above what was measured, and the stated range ends above it.
By their numbers in this assay, from the lowest: compounds 3 and 1 (each within the scatter of the next); then compound 2.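

In this assay, the change from methyl to octyl on the sulfonamide nitrogen strengthens the inhibition, with a step of a 6.7-fold lower number from compound 2 to compound 3 (0.82 log units; beyond the scatter), so a long chain at this place is compatible with stronger inhibition than the methyl gives. Compound 2, the only compound shown with a methyl on that nitrogen, now stands as the weakest of the three, since its steps to both others are beyond the scatter; the octyl chain alone does not go with the weak number, as compound 3 carries octyl as well and gives the lower number. No measurement shown here accounts for this step, so the reason for it remains unknown.

The compounds shown span only methyl, butyl and octyl on this nitrogen, so it stays open how an ethyl or butyl chain paired with octyl would read, and whether a longer chain such as dodecyl would continue the step or reverse it. Also open, as far as these compounds go, is how a ring such as cyclohexyl or benzyl, or an amine or a carboxylic acid at the end of the chain, would read in this assay.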